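Swapping a Large Aryl Amide for a Small Hydroxyethyl Amide

The source may report more compounds than this note shows. Statements on the series, on what has been measured and on what is new or still open speak of the compounds shown alone.

Measured compounds:
compound 1, `CCn1c(C(=O)NCCN(C)C)ccc1C(CC)(CC)c1ccc(OCCC(O)(CC)CC)c(C)c1`: 240 nM
compound 2, `C#CCCOC(=O)c1ccc(C(CC)(CC)c2ccc(OCCC(O)(CC)CC)c(C)c2)n1CC`: > 50000 nM
compound 3, `CCn1c(C(=O)Nc2cccc(C(F)(F)F)c2)ccc1C(CC)(CC)c1ccc(OCCC(O)(CC)CC)c(C)c1`: > 50000 nM

In a functional assay on HepG2 cells (Homo sapiens) for antiproliferative activity, read by MTT assay, with a stated time of 48 h (a higher number here means a weaker inhibitor, a lower number a stronger inhibitor), compound 1 gives 240 nM. Compound 2 reaches only the limit of the assay, > 50000 nM. Compound 3 likewise reaches only the limit of the assay, > 50000 nM. So compound 3 stands at the limit of > 50000 nM in this assay, at which 2 of the 3 values shown sit, with no number of its own, and only compound 1 has a measured value.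

Compound 4 is `CCn1c(C(=O)N(C)CCO)ccc1C(CC)(CC)c1ccc(OCCC(O)(CC)CC)c(C)c1`. It differs from compound 3 at one place: (2-hydroxyethyl)(methyl)amino in place of (3-(trifluoromethyl)phenyl)amino on a carbonyl carbon.

Within the data shown here, two measured steps bear on this. Going from the small amide of compound 1 to either the ester or the aryl amide gives an at least 200-fold higher number from compound 1 to compound 2 (2.31 log units; beyond the scatter) and an at least 200-fold higher number from compound 1 to compound 3 (2.31 log units; beyond the scatter), while a step that the two limits leave unreadable from compound 2 to compound 3. Compound 4 returns to a small, chain-like amide as in compound 1, so a large step back toward lower numbers is expected: an at least 33-fold lower number from compound 3 to compound 4 (1.52 log units; beyond the scatter). Compound 4 is therefore estimated at 1500 nM, within a range from 200 nM to 20000 nM.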

Compound 4, half-maximal inhibitory concentration: 510 nM
Compound 4: the middle estimate sits 2.9-fold (0.47 log units) above what was measured; low and high end bracket the measured number.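

In this assay, putting (2-hydroxyethyl)(methyl)amino on the carbonyl carbon in place of (3-(trifluoromethyl)phenyl)amino gives an at least 98-fold lower number from compound 3 to compound 4 (1.99 log units; beyond the scatter), and putting it in place of (but-3-yn-1-yl)oxy gives an at least 98-fold lower number from compound 2 to compound 4 (1.99 log units; beyond the scatter). Among these compounds, good activity at this position is therefore not tied to the 2-(dimethylamino)ethyl chain of compound 1, since exchanging that amide for the hydroxyethyl amide gives only a modest change: a 2.1-fold higher number from compound 1 to compound 4 (0.33 log units; beyond the scatter). Compound 2 and compound 3 each stand at a limit, so the two large steps give only a minimum size: the limit of > 50000 nM in this assay, at which 2 of the 4 values shown sit.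

From the compounds shown here alone, what remains open is which part of the new group matters, the hydroxyl or the methyl on the amide nitrogen. A plain ethyl amide, a chain ending in a carboxylic acid, or a longer hydroxyalkyl chain at this carbonyl carbon would help to separate these.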